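This account rests on a few compounds, and the source may have more. Where it says the series, first, only, none or still open, it means among the compounds named here.

Of the compounds shown here, two sharing one core have been measured so far. Compound 1 `Cc1ccc(S/C(=C/c2ccc(Br)cc2)C(=O)c2ccc(Cl)cc2)cc1` gives 25000 nM in a functional assay on DU-145 cells (Homo sapiens) for inhibition, read by trypan blue exclusion, with a stated time of 96 h (on this read-out higher numbers stand for weaker inhibition of growth and lower numbers for stronger inhibition of growth), the highest of the two numbers seen. For the measured compounds named here, compound 2 `Cc1ccc(S/C(=C/c2ccc[nH]2)C(=O)c2ccc(Cl)cc2)cc1` gives 10000 nM in this assay, and the step of a 2.5-fold lower number from compound 1 to compound 2 (0.40 log units; beyond the scatter) is the only measured comparison available. Compound 3 `O=C(/C(=C\c1ccc(Br)cc1)SCc1ccc(F)cc1)c1ccc(Cl)cc1` has not yet been measured in this assay. It differs from compound 1 by 4-fluorobenzyl in place of 4-methylphenyl on a sulfur. Going by the values given here, the one measured step concerns a change on a double-bonded chain carbon, not on the sulfur, so no measured step bears on the change from compound 1 to compound 3, and the numbers give nothing to set a direction. The step expected in this assay is therefore a 1.3-fold lower number from compound 1 to compound 3 (0.10 log units; within the scatter), which is none beyond the scatter. Compound 3 is accordingly estimated at 20000 nM in this assay, with a range from 5000 nM to 80000 nM.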

Compound 3, concentration for 50% growth inhibition: 9000 nM
Estimate against measurement, compound 3: 2.2-fold (0.35 log units) above; low and high end bracket the measured number.
By their numbers in this assay, from the lowest: compounds 3 and 2 (each within the scatter of the next); then compound 1.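

In this assay, the group on the sulfur proves to matter: 4-fluorobenzyl in place of 4-methylphenyl gives a 2.8-fold lower number from compound 1 to compound 3 (0.44 log units; beyond the scatter). For the compounds shown here, this is the first measured change at this position, as the earlier comparison concerned only the double-bonded chain carbon, and it shows that a change on the sulfur can give a modest step beyond the scatter while the 4-bromophenyl group stays in place. Nothing available accounts for this step.

The change replaces a phenyl link with a benzyl link and a methyl group with a fluorine at once, so the compounds shown leave open which of the two carries the step; unsubstituted benzyl or 4-methylbenzyl on the sulfur would separate them. Also open, as far as these compounds go, is whether the step holds when 1H-pyrrol-2-yl replaces 4-bromophenyl.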